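A few compounds are considered here, and "the series" means these few. Any claim that something is new, unique, unknown or untested is made for them only; others in the source may bear on it.

Measured so far in a functional assay on MDA-MB-231 cells (Homo sapiens) for inhibition, read by MTT assay, with stated times of 18 h and 4 h (a higher number here means a weaker inhibitor, a lower number a stronger inhibitor), for the series:
- compound 1 `CCCCCCCCCCOP(=O)(O)OCCSC(=S)N1CCN(C)CC1` gives 29000 nM
- compound 2 `CCCCCCOP(=O)(O)OCCSC(=S)N1CCN(C)CC1` gives 73000 nM

Compound 2, at 73000 nM in this assay, has the higher of the two numbers and is the weaker inhibitor of the pair. Compound 3 `CCCOP(=O)(O)OCCSC(=S)N1CCN(C)CC1` is still unmeasured. It differs from compound 2 by hexyl to propyl hydrogen in place of propyl on a saturated chain carbon, three bonds along the chain from an oxygen on an unsaturated carbon on the shared core.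

Among the compounds with values here, only one measured step bears on this, a 2.5-fold higher number from compound 1 to compound 2 (0.40 log units; beyond the scatter), where hydrogen replaces butyl on the same chain. That step is modest, and a single step sets no firm trend. A further modest rise of similar size is expected in this assay, towards weaker inhibition. The expected step is a 2.1-fold higher number from compound 2 to compound 3 (0.31 log units; beyond the scatter) as estimated here. Compound 3 is estimated at 150000 nM with an expected range from 80000 nM to 300000 nM for now.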

Compound 3, half-maximal inhibitory concentration: 62000 nM
The estimate for compound 3 lay 2.4-fold (0.38 log units) above the measured number; the measured number lies below the stated range.
By their numbers in this assay, from the lowest: compound 1; then compounds 3 and 2 (each within the scatter of the next).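

Going from hexyl to propyl at this position gives a small step in this assay (a 1.2-fold lower number from compound 2 to compound 3 (0.07 log units; within the scatter)), so compound 2 and compound 3 cannot be told apart here. The step from the longer chain of compound 1 to the propyl chain is of modest size (a 2.1-fold higher number from compound 1 to compound 3 (0.33 log units; beyond the scatter)) and close to the step already seen with hexyl, so among these three compounds only compound 1 stands apart, and the numbers do not follow chain length evenly. No available data explain this reading.

On these data alone, it remains open whether a chain longer than that of compound 1 would lower the number further, or whether the step seen with compound 1 is the limit of the effect. Also open, as far as these compounds go, is how a chain ending in an amine or a carboxylic acid would read at this position.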